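The source may hold more compounds than are shown below. What is called first, only, known or untested is meant among the compounds shown, and "the series" means these compounds.

Measured compounds:
compound 1 `O=C(NCN1CCC(c2cccc[n+]2[O-])CC1)c1cnccc1Cl` — 1290 nM
compound 2 `O=C(CN1CCC(c2cccc[n+]2[O-])CC1)Nc1ccc(F)cc1F` — 103 nM
compound 3 `Cc1cccc(NC(=O)CN2CCC(c3ccccc3)CC2)c1` — 170 nM

In a functional assay on HEK293 cells for agonist activity at D(4) dopamine receptor (Homo sapiens), read by FLIPR (a higher number here means that more compound is needed for the effect, a lower number that less compound is needed), compound 1 gives 1290 nM, the highest number of the three measured. Going by the values given here, compound 3 gives 170 nM and compound 2 gives 103 nM; both gaps to compound 1 lie beyond the usual scatter, so compound 1 is the weakest agonist of the three measured so far.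

The next compound, compound 4 `Cc1cccc(C(=O)NCN2CCC(c3cccc[n+]3[O-])CC2)c1`, keeps the core of compound 1 and differs from it in one place: 3-methylphenyl in place of 4-chloropyridin-3-yl on a carbonyl carbon. Among the compounds with values here, no pair of measured compounds differs by exactly this change, so the size of the step has no measured precedent in this set. Compound 3 also carries a 3-methylphenyl, but it differs from compound 4 in more than one place and gives no direct read on the exchange.

Given that compound 1 stands at the weak end of the series and that the other two measured compounds give lower numbers, the expectation is a step downward of moderate size, a 2.6-fold lower number from compound 1 to compound 4 (0.41 log units; beyond the scatter), rather than none beyond the scatter. For compound 4 the estimated value in this assay is 500 nM, with a range from 150 nM to 1800 nM.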

Compound 4, half-maximal effective concentration: 89 nM
For compound 4 the middle estimate is 5.6-fold (0.75 log units) above the measured one; measured number outside the range, below it.
By their numbers in this assay, from the lowest: compounds 4, 2 and 3 (each within the scatter of the next); then compound 1.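

In this assay, the exchange on a carbonyl carbon whose other neighbour is an amide-type nitrogen gives a 14-fold lower number from compound 1 to compound 4 (1.16 log units; beyond the scatter), a large step that is set by this one place alone, since the rest of the molecule stays the same. Going by these compounds alone, the earlier compounds differed from one another in more than one place and offered no measured step, so this is the first direct read on how far this place can move the number. Both groups are six-membered aromatic rings with the same heavy-atom count, so the step does not come with a change in that count; it comes with a change in ring atoms and substituent, as 4-chloropyridin-3-yl carries nitrogen and chlorine and 3-methylphenyl carbon only.

The ring nitrogen, the chlorine and the methyl all change together here, so their shares in the step stay unresolved, and an unsubstituted phenyl, a 3-chlorophenyl or a methoxyphenyl on the same carbonyl carbon would begin to separate them. Nothing at hand bears on the reason for the step.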